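The source may report more compounds than this note shows. Statements on the series, on what has been measured and on what is new or still open speak of the compounds shown alone.

In an ADME assay on A549 cells (Homo sapiens) for cytotoxicity, read by resazurin assay, with a stated time of 48 h (a higher number here means that more compound is tolerated, a lower number that less compound is tolerated), compound 1 (`CCNc1ccc(NC(=O)c2cc(Cl)ccc2O)c(Cl)c1`) gives 30200 nM and compound 2 (`CCCNc1ccc(NC(=O)c2cc(Cl)ccc2O)c(Cl)c1`) gives 22500 nM, the two together forming the tolerated end of the series, while compound 3 (`CC(C)Nc1ccc(NC(=O)c2cc(Cl)ccc2O)c(Cl)c1`) gives 11000 nM. Compound 4 (`CC(C)CNc1ccc(NC(=O)c2cc(Cl)ccc2O)c(Cl)c1`) remains unmeasured. It differs from compound 1 by isopropyl in place of methyl on a saturated chain carbon bound to a nitrogen on an aromatic ring. The nearest evidence is a 1.3-fold lower number from compound 1 to compound 2 (0.13 log units; within the scatter), and a 2.7-fold lower number from compound 1 to compound 3 (0.44 log units; beyond the scatter). Both added carbon and branching therefore point to a modest expected step towards a lower number in this assay. The estimated value for compound 4 is 15000 nM, with an expected range of 7500 nM to 28000 nM. The expected change is a 2.0-fold lower number from compound 1 to compound 4 (0.30 log units; within the scatter).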

Compound 4, half-maximal cytotoxic concentration: 60000 nM
Compound 4: the middle estimate sits 4.0-fold (0.60 log units) below what was measured; measured number outside the range, above it.
By their numbers in this assay, from the lowest: compound 3; then compounds 2, 1 and 4 (each within the scatter of the next, the first and the last beyond it).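

Ethylamino to isobutylamino gives a 2.0-fold higher number from compound 1 to compound 4 (0.30 log units; within the scatter), so in this assay added carbon at this position brings no step beyond the scatter. Isobutyl in place of isopropyl gives a 5.5-fold higher number from compound 3 to compound 4 (0.74 log units; beyond the scatter), and methyl in place of hydrogen on the propyl chain gives a 2.7-fold higher number from compound 2 to compound 4 (0.43 log units; beyond the scatter). The same added methyl therefore moves the number in opposite directions, depending on the chain that carries it: the same change on two cores in this assay, a 2.7-fold lower number (0.44 log units; beyond the scatter) from compound 1 to compound 3 and a 2.7-fold higher number (0.43 log units; beyond the scatter) from compound 2 to compound 4, 7.3-fold (0.86 log units) apart, beyond the scatter of two such steps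

From the compounds shown here alone, whether the value seen with isobutyl carries over to a longer chain such as pentyl, or to cyclopropylmethyl on the same nitrogen, remains open.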